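The source may report more compounds than this note shows. Statements on the series, on what has been measured and on what is new or still open speak of the compounds shown alone.

In a functional assay on HPC cells (Homo sapiens) for cytotoxicity (on this read-out higher numbers stand for lower toxicity in this test and lower numbers for higher toxicity in this test), compound 1 `COc1cc(/C=C2\CCC/C(=C\c3ccc([N+](=O)[O-])cc3)C2=O)ccc1O` reaches only the limit of the test, giving > 400000 nM. Compound 2 `COc1cc(/C=C2\Cc3ccccc3/C(=C\c3ccc([N+](=O)[O-])cc3)C2=O)cc(OC)c1OC` likewise shows only a limit, with > 400000 nM. Compound 3 `COc1ccc(/C=C2\Cc3ccccc3/C(=C\c3ccc([N+](=O)[O-])cc3)C2=O)cc1` also stops at a limit, at > 400000 nM. Going by the values given here, all three therefore sit at the same boundary, (the limit of > 400000 nM in this assay, at which 3 of the 3 values shown sit), so no measured step between them can be read. Compound 4 `COc1ccc(/C=C2\CCC/C(=C\c3ccc([N+](=O)[O-])cc3)C2=O)cc1OC` differs from compound 1 by methyl in place of hydrogen on an oxygen on an aromatic ring, the same difference one bond further out reading hydroxy to methoxy. Since compound 1 itself gives > 400000 nM, a limit, the change from compound 1 to compound 4 is expected to lie within the scatter, a number no higher from compound 1 to compound 4 (the limit leaves the size open), and compound 4 is expected to show about 400000 nM, within 200000 nM to 1000000 nM, most likely again as a limit.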

Compound 4, half-maximal cytotoxic concentration: 82000 nM
Estimate against measurement, compound 4: 4.9-fold (0.69 log units) above, outside the stated range (below it).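

Methyl in place of hydrogen on an oxygen on an aromatic ring brings an at least 4.8-fold lower number from compound 1 to compound 4 (0.68 log units; beyond the scatter) and is the first change here to move the number in this assay off the limit. This position therefore registers in the read-out, with the methoxy of compound 4 going with higher toxicity in this test than the hydroxy of compound 1. On these data alone, the true size of the step stays unknown because compound 1 gives only a limit: the limit of > 400000 nM in this assay, at which 3 of the 4 values shown sit.

As far as these compounds go, whether a longer chain such as ethyl on that oxygen, or an amine in place of the oxygen group, would shift the number further remains open.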